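The source may hold more compounds than are shown below. What is called first, only, known or untested is meant among the compounds shown, and "the series" means these compounds.

Of the compounds shown here, three have been measured so far in a functional assay on DU-145 cells (Homo sapiens) for inhibition, read by trypan blue exclusion, with a stated time of 96 h; on this read-out higher numbers stand for weaker inhibition of growth and lower numbers for stronger inhibition of growth. Compound 1 `COc1ccc(/C=C(/SCc2ccc(Cl)cc2)C(=O)c2ccc(Br)cc2)cc1` gives 10000 nM, compound 2 `O=C(/C(=C\c1ccc(Br)c(O)c1)S(=O)(=O)c1ccc(Br)cc1)c1ccc(Br)cc1` gives 50000 nM, and compound 3 `Cc1ccc(S/C(=C/c2ccc(Cl)c(Cl)c2)C(=O)c2ccc(Br)cc2)cc1` gives 50000 nM. On these numbers compound 3 stands level with compound 2 at the digits shown, and the two together hold the highest numbers, while compound 1 sits at a lower number, a gap beyond the scatter. Compound 4 `Cc1ccc(S/C(=C/c2ccc(C)s2)C(=O)c2ccc(Br)cc2)cc1` has not yet been measured. It differs from compound 3 in one place: 5-methylthiophen-2-yl in place of 3,4-dichlorophenyl on a double-bonded chain carbon bound to a double-bonded chain carbon. Within the data shown here, no measured compound carries this new group, so the data give no guide to its effect, and no step beyond the scatter is expected in this assay. Compound 4 is therefore estimated at 50000 nM, within a range from 15000 nM to 150000 nM. This estimate means an expected step of no change at the digits printed from compound 3 to compound 4 (within the scatter) that lies within the scatter.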

Compound 4, concentration for 50% growth inhibition: > 100000 nM
Compound 4 was reported as a limit (the forecaster's own chance of this, stated with the estimate: 30%); middle value at least 2.0-fold (0.30 log units) from the limit.
By their numbers in this assay, from the lowest: compound 1; then compounds 2 and 3 (each within the scatter of the next). At a limit, above all of these: compound 4.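

Among these compounds, the step of an at least 2.0-fold higher number from compound 3 to compound 4 (0.30 log units; that floor lies within the scatter) is the first single-place change that can be read, with 5-methylthiophen-2-yl in place of 3,4-dichlorophenyl on a double-bonded chain carbon bound to a double-bonded chain carbon. Compound 4 gives > 100000 nM, which is a limit and not a number. Among the compounds shown here, the floor of this step lies within the scatter, so the result shows only that this swap brought no gain in growth inhibition.

Which part of the swap matters, the ring or its substituents, stays open. So does whether an amine or a carboxylic acid at this place would give a lower number.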